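The source may hold more compounds than are shown below. What is called first, only, known or untested is meant among the compounds shown, and "the series" means these compounds.

Measured so far:
- compound 1, `N#Cc1ccccc1C1OCC(C/C=C\CCC(=O)O)C(c2cccnc2)O1`: in an assay for inhibition of prostacyclin synthase (Homo sapiens), using microsomes (on this read-out higher numbers stand for weaker inhibition and lower numbers for stronger inhibition), compound 1 gives > 100000 nM, a limit of the assay.
- compound 2, `Cc1ccc(C#N)c(OC(C)(C)C2OCC(C/C=C\CCC(=O)O)C(c3cccnc3)O2)c1`: in this assay compound 2 gives > 100000 nM, also a limit.
- compound 3, `CC(C)(Oc1ccccc1Br)C1OCC(C/C=C\CCC(=O)O)C(c2cccnc2)O1`: in this assay compound 3 gives 7000 nM.

For the measured compounds named here, compound 3 thus holds the only actual number; the other two results sit at the limit of > 100000 nM in this assay, at which 2 of the 3 values shown sit.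

Compound 4, `CC(C)(Cc1ccccc1)C1OCC(C/C=C\CCC(=O)O)C(c2cccnc2)O1`, differs from compound 3 by benzyl in place of 2-bromophenoxy on a saturated chain carbon bound to two saturated chain carbons and a saturated ring carbon. Going by the values given here, the single measured step, an at least 14-fold lower number from compound 2 to compound 3 (1.15 log units; beyond the scatter), was large, but it exchanged one aromatic group for another while keeping the oxygen, so it bears only loosely on a change that removes the oxygen. Direction is therefore uncertain; a step of a 2.9-fold higher number from compound 3 to compound 4 (0.46 log units; beyond the scatter) toward weaker inhibition is expected, with a wide range. Compound 4 is estimated at 20000 nM, between 4000 nM and 100000 nM.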

Compound 4, half-maximal inhibitory concentration: 13000 nM
The estimate for compound 4 lay 1.5-fold (0.19 log units) above the measured number, and the stated range covers the measured number.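

On the saturated chain carbon bound to two saturated chain carbons and a saturated ring carbon, the oxygen of 2-bromophenoxy is not required for a measurable number: benzyl in its place gives no change beyond the scatter (a 1.9-fold higher number from compound 3 to compound 4 (0.27 log units; within the scatter)). Benzyl also compares clearly with the groups of compound 2 (an at least 7.6-fold lower number from compound 2 to compound 4 (0.88 log units; beyond the scatter)) and compound 1 (an at least 7.6-fold lower number from compound 1 to compound 4 (0.88 log units; beyond the scatter)). Both of those steps start from a limit, not a number: the limit of > 100000 nM in this assay, at which 2 of the 4 values shown sit.

Open, as far as these compounds go, is whether the bromine contributes, as 2-bromobenzyl on this carbon would test. Also open, from the compounds shown here alone, is how an amine or a longer chain at this place would read.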